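Cyclohexyl in Place of Butyl on the Amide Nitrogen

The source may report more compounds than this note shows. Statements on the series, on what has been measured and on what is new or still open speak of the compounds shown alone.

Measured compounds:
compound 1 `CCNC(=O)CC1CCc2cc(OC)c(OC)cc21`, 33.3%
compound 2 `CCCCNC(=O)CC1CCc2cc(OC)c(OC)cc21`, 36.7%

In a functional assay on the whole organism (strain Wistar) for inhibition, with Rattus norvegicus as the target, read by paw edema, with stated times of 60 min and 24 h, at a dose of 100 mg/kg by the oral route (a higher number here means more inhibition at the dose given (going by the name of the read-out), a lower number less inhibition), compound 1 gives 33.3% and compound 2 gives 36.7%. Compound 2 holds the upper of the two numbers, but the step of a number 3.4 percentage points higher from compound 1 to compound 2 (within the scatter) lies within the scatter, so the two compounds are not told apart. Compound 3 `COc1cc2c(cc1OC)C(CC(=O)NC1CCCCC1)CC2` carries cyclohexyl in place of butyl on an amide-type nitrogen. Going by the values given here, the only measured step, a longer chain on the same nitrogen, changed nothing beyond the scatter; no measured step shows a ring entering there. The step of a number 3.3 percentage points higher from compound 2 to compound 3 (within the scatter) is therefore expected to stay small, without a clear direction. Compound 3 is estimated at 40%, between 25% and 55%.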

Compound 3, a percentage reported as inhibition, in the whole organism at one dose (the size of the read-out at that dose, not a potency): 53.3%
For compound 3 the middle estimate is 13.3 percentage points below the measured one; measured number inside the range.
By their numbers in this assay, from the lowest: compounds 1 and 2 (each within the scatter of the next); then compound 3.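

On the amide-type nitrogen, the shape of the group now matters: in this assay cyclohexyl in place of butyl gives a number 16.6 percentage points higher from compound 2 to compound 3 (beyond the scatter) and cyclohexyl in place of ethyl gives a number 20 percentage points higher from compound 1 to compound 3 (beyond the scatter) on the same shared core. The earlier change from ethyl to butyl, an open chain made longer, gave no such separation. Nothing here explains the gain. Going by these compounds, whether it comes from the ring itself or simply from the six carbons stays open. A straight hexyl chain, a cyclopentyl ring or a phenyl ring on the same nitrogen would help separate these possibilities.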